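This account rests on a few compounds, and the source may have more. Where it says the series, first, only, none or still open, it means among the compounds named here.

Measured so far:
compound 1 `Nc1nccn2cc(-c3ccccc3)nc12`: 12% in an assay on cells for displacement of a labelled ligand from transmembrane domain-containing protein TMIGD3 (Homo sapiens), read by scintillation counting, with a stated time of 120 min, tested at 1 uM; a higher number here means more inhibition at the concentration tested (going by the name of the read-out), a lower number less inhibition
compound 2 `Cc1ccc(C(=O)Nc2nccn3cc(-c4ccccc4)nc23)cc1`: 45% in this assay

On the two numbers available, compound 2 stands highest; its nearest neighbour is compound 1, which gives 12%, a gap beyond the scatter. Both share the core of compound 1, and the amide of compound 2 is the only addition to it. Compound 3 `O=C(Nc1nccn2cc(-c3ccccc3)nc12)c1ccco1` keeps that amide and differs from compound 2 in one place: furan-2-yl in place of 4-methylphenyl on a carbonyl carbon. Within the data shown here, no step between measured compounds concerns an exchange of this kind, so the present numbers say nothing about how the ring on the carbonyl carbon bears on the read-out. What they do show is that the acylated compound 2 sits clearly above the free amine of compound 1, so the part of the molecule that carries the gain is retained in compound 3, while the exchange of the ring may give up some of it. The step of a number 10 percentage points lower from compound 2 to compound 3 (within the scatter) is expected to be a modest fall, possibly none beyond the scatter. Compound 3 is therefore estimated at 35%. The expected range for compound 3 runs from 15% to 55%.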

Compound 3, a percentage reported as inhibition, at one concentration (the size of the read-out at that concentration, not a potency): 40%
Compound 3: middle estimate off by 5 percentage points, on the low side, and the stated range covers the measured number.
By their numbers in this assay, from the lowest: compound 1; then compounds 3 and 2 (each within the scatter of the next).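

In this assay, furan-2-yl in place of 4-methylphenyl on a carbonyl carbon gives a number 5 percentage points lower from compound 2 to compound 3 (within the scatter), so at this position the two rings cannot be told apart, despite their different ring size and the hetero atom that furan-2-yl brings. The (furan-2-yl)carbonyl in place of hydrogen on a nitrogen on an aromatic ring gives a number 28 percentage points higher from compound 1 to compound 3 (beyond the scatter), which shows directly, in a single change, that acylating the free amine of the shared core raises the read-out, and compound 2 shows from its printed value that this is not confined to the furan-2-yl amide. No independent data bear on why the read-out responds in this way.

Still open, as far as these compounds go, is whether a ring on the carbonyl carbon is needed at all, a question that an acetyl group or a longer alkyl chain at that place would address. Also open, from the compounds shown here alone, is how the read-out responds to an amine or a carboxylic acid carried on that ring, and whether any of these amides would separate from compound 2 and compound 3 by more than the scatter.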